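A few compounds are considered here, and "the series" means these few. Any claim that something is new, unique, unknown or untested is made for them only; others in the source may bear on it.

Three compounds sharing one core were tested in a functional assay, with a stated time of 6 min; on this read-out higher numbers stand for weaker inhibition and lower numbers for stronger inhibition. Compound 1, `S=c1[nH]nc(-c2ccc3c(c2)OCCO3)o1`, gives 10600 nM. Compound 2, `S=c1oc(-c2ccc3c(c2)OCCO3)nn1CNc1ccc(Cl)cc1Cl`, gives 8710 nM, and compound 3, `O=[N+]([O-])c1ccc(NCn2nc(-c3ccc4c(c3)OCCO4)oc2=S)c(Cl)c1`, gives 8660 nM. Among the compounds with values here, compound 2 stands second highest of these three numbers; its gap to compound 1 lies within the scatter, and the one measured step starting from it, nitro in place of chloro on an aromatic carbon, was a 1.0-fold lower number from compound 2 to compound 3 (0.00 log units; within the scatter), also within the scatter. Compound 4, `Cc1ccc(NCn2nc(-c3ccc4c(c3)OCCO4)oc2=S)cc1`, has not yet been measured and differs from compound 2 in one place: 4-methylphenyl in place of 2,4-dichlorophenyl on an amine nitrogen. Within the data shown here, the only measured step that bears on this part of the molecule is the one from compound 2 to compound 3, and it moved the number not at all; compound 1, which lacks this group altogether, also lies within the scatter of compound 2. Compound 4 is therefore expected to show no step beyond the scatter in this assay from compound 2, an estimated 1.0-fold higher number from compound 2 to compound 4 (0.01 log units; within the scatter). Compound 4 is estimated at 9000 nM, with an expected range from 3500 nM to 25000 nM.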

Compound 4, half-maximal inhibitory concentration: 5700 nM
The estimate for compound 4 lay 1.6-fold (0.20 log units) above the measured number; the measured number falls inside the stated range.
By their numbers in this assay, from the lowest: compounds 4, 3, 2 and 1 (each within the scatter of the next).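

In this assay, 4-methylphenyl in place of 2,4-dichlorophenyl on the amine nitrogen gave a 1.5-fold lower number from compound 2 to compound 4 (0.18 log units; within the scatter). Unlike the earlier step, which kept one chlorine on the ring, this change leaves no chlorine there, and the result still stays within the scatter, so this position accepts an all-carbon aromatic group as well as the halogen-bearing ones shown. Nothing available bears on why this step has the size it has. 

The compounds shown leave open whether any group at this position can move the number beyond the scatter, since all four compounds remain within the scatter of their neighbours in the ranking. A carboxylic acid or a methoxy group on this ring, or a saturated cyclohexyl ring in place of the aromatic ring, could test this.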